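This account rests on a few compounds, and the source may have more. Where it says the series, first, only, none or still open, it means among the compounds named here.

Working notes on the pair around compound 1 `ClCc1ccccc1Cn1cnc2c(Cl)nc(Cl)nc21`. In a functional assay on OVCAR-8 cells (Homo sapiens) for cytotoxicity, read by sulforhodamine B assay, with a stated time of 48 h (a higher number here means that more compound is tolerated, a lower number that less compound is tolerated), compound 1 gives 6450 nM, the lower of the two numbers in hand. Compound 2 `ClCc1ccc(Cn2cnc3c(Cl)nc(Cl)nc32)cc1` differs from compound 1 only in the placement of the chloromethyl group on the benzyl ring. In this assay compound 2 gives 72400 nM, a gap that lies beyond the usual scatter, so compound 1 is the more potent of the two.

Compound 3 `Nc1nc(Cl)c2ncn(Cc3ccccc3CCl)c2n1` is not yet measured. Relative to compound 1 it shows amino in place of chloro on an aromatic carbon, between two ring nitrogen atoms of the shared core. Among the measured compounds shown here, no step of this kind exists among the measured compounds, so the direction rests on nothing measured. The chloromethyl group on the benzyl ring, common to compound 1 and compound 2, is retained in compound 3. The expectation is a modest step of a 2.3-fold higher number from compound 1 to compound 3 (0.37 log units; beyond the scatter) towards a higher number, though a result within the scatter would not surprise. Compound 3 is estimated at 15000 nM in this assay, with a range from 4000 nM to 60000 nM.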

Compound 3, concentration lethal to 50% of the cells: > 100000 nM
Compound 3 ended at the assay's limit (the forecaster's own chance of this, stated with the estimate: 5%); at least 6.6-fold (0.82 log units) between middle value and limit.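

In this assay compound 3 gives > 100000 nM, which is a limit of the assay and not a number. Among the compounds shown here, this is the first measured change on the shared core rather than on the benzyl ring, and it shows that this position, between two ring nitrogen atoms, is not indifferent: amino in place of chloro on an aromatic carbon gives an at least 15-fold higher number from compound 1 to compound 3 (1.19 log units; beyond the scatter), so much less of compound 3 than of compound 1 is needed to reach no effect is not the reading, but rather that far more of it is tolerated. The printed step is a lower bound on the true gap, and its full size stays unread: the limit of > 100000 nM in this assay, at which 1 of the 3 values shown sits.

The compounds shown cannot separate the departure of chloro from the arrival of amino, so a methoxy or dimethylamino group at this position would be needed to tell whether any replacement of chloro raises the number or amino does so in particular. Going by these compounds, it also remains open whether the same step holds with the chloromethyl group placed as in compound 2, and whether the chloro group that stays on the core in compound 3 matters to the result.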